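A few compounds are considered here, and "the series" means these few. Any claim that something is new, unique, unknown or untested is made for them only; others in the source may bear on it.

Of the compounds shown here, two from this study have been tested in an assay on cells for displacement of a labelled ligand from adenosine receptor A3 (Homo sapiens), read by scintillation counting and radioligand binding, with a stated time of 180 min, tested at 10 uM; a higher number here means more inhibition at the concentration tested (going by the name of the read-out), a lower number less inhibition. Compound 1, `Cn1cnc2c(N3CCCCC3)nc(-c3ccccc3O)nc21`, gives 20% in this assay. Compound 2, `CN1CCN(c2nc(-c3ccc(Cl)c(Cl)c3)nc3c2ncn3C)CC1`, gives 35.3% in this assay, and this is the higher of the two numbers; the gap to compound 1 lies beyond the usual scatter of this measurement.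

The next compound, compound 3, `CN1CCN(c2nc(-c3ccccc3O)nc3c2ncn3C)CC1`, has not yet been measured in this assay. It keeps the core of compound 2 with its 4-methylpiperazin-1-yl group and changes the aromatic ring in one place: 2-hydroxyphenyl in place of 3,4-dichlorophenyl on an aromatic carbon. The 2-hydroxyphenyl group that enters is the same group that compound 1 already carries, and compound 1 sits at the lower of the two measured values.

Among the measured compounds shown here, no pair of measured compounds differing only in this place exists, so the size of the step is uncertain. A modest decrease is expected, with a step from compound 2 to compound 3 of a number 14.3 percentage points lower from compound 2 to compound 3 (beyond the scatter) in this assay. Compound 3 is therefore estimated at 21%, with a range from 5% to 38%.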

Compound 3, a percentage reported as inhibition, at one concentration (the size of the read-out at that concentration, not a potency): 15.3%
Estimate against measurement, compound 3: 5.7 percentage points above; measured number inside the range.
By their numbers in this assay, from the lowest: compounds 3 and 1 (each within the scatter of the next); then compound 2.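

In this assay, the aromatic carbon between two ring nitrogen atoms now has a direct test: with the 4-methylpiperazin-1-yl group held constant, 2-hydroxyphenyl in place of 3,4-dichlorophenyl gives a number 20 percentage points lower from compound 2 to compound 3 (beyond the scatter), so the group at this carbon makes a measurable difference. The other single change, with 2-hydroxyphenyl kept in place, is 4-methylpiperazin-1-yl in place of piperidin-1-yl, and it gives a number 4.7 percentage points lower from compound 1 to compound 3 (within the scatter), which means that the two groups cannot be told apart in this measurement when 2-hydroxyphenyl is present. No measurement at hand bears on why either step has the size it has.

The compounds shown leave open whether the first step follows from losing the chlorine atoms or from gaining the hydroxy group, a separation that a plain phenyl or a 4-chlorophenyl group at the same carbon could provide. Also open, going by these compounds, is whether piperidin-1-yl and 4-methylpiperazin-1-yl would still read alike alongside 3,4-dichlorophenyl, and how a small open-chain amine such as dimethylamino would behave in their place.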